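Swapping a dichloroanilino for trifluoromethylphenyl on the carbonyl

The compounds below may be only part of what the source reports. "The series", "measured", "known", "first", "only" and "open" are said of these compounds alone.

Two compounds share one core and differ only in the aryl group on the outer nitrogen: compound 1 `O=C(Nc1ccc(-n2ccc3c(NC(=O)c4ccccc4)ncnc32)cc1)Nc1cccc(Cl)c1Cl` and compound 2 `O=C(Nc1ccc(-n2ccc3c(NC(=O)c4ccccc4)ncnc32)cc1)Nc1ccc(Cl)c(Cl)c1`. In a functional assay on A375P cells (Homo sapiens) for antiproliferative activity, read by MTT assay, with a stated time of 24 h (a lower number here means a stronger inhibitor, a higher number a weaker inhibitor), compound 1 gives 4100 nM, and compound 2 gives 4000 nM. For the measured compounds named here, the step of a 1.0-fold lower number from compound 1 to compound 2 (0.01 log units; within the scatter) shows that moving the two chlorines around the ring changes nothing beyond the scatter, and compound 2 therefore stands level with the only other number available. Compound 3 `O=C(Nc1ccc(-n2ccc3c(NC(=O)c4ccccc4)ncnc32)cc1)c1cccc(C(F)(F)F)c1` makes a different change: 3-(trifluoromethyl)phenyl in place of (3,4-dichlorophenyl)amino on a carbonyl carbon, so the carbonyl carbon now carries an aryl group directly rather than an arylamino group. Going by the values given here, no measured step touches this kind of change; the one step known, from compound 1 to compound 2, only says the region tolerates a rearranged dichlorophenyl. The expectation is thus a step of no change at the digits printed from compound 2 to compound 3 (within the scatter) with wide uncertainty, and compound 3 is estimated at 4000 nM, between 1300 nM and 12000 nM.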

Compound 3, half-maximal inhibitory concentration: 4700 nM
Estimate against measurement, compound 3: 1.2-fold (0.07 log units) below; measured number inside the range.
By their numbers in this assay, from the lowest: compounds 2, 1 and 3 (each within the scatter of the next).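

In this assay, putting an aryl group directly on the carbonyl carbon in place of an arylamino group gives a 1.2-fold higher number from compound 2 to compound 3 (0.07 log units; within the scatter) and, against the other dichlorophenyl isomer, a 1.1-fold higher number from compound 1 to compound 3 (0.06 log units; within the scatter). For the compounds shown here, this position therefore tolerates losing the outer nitrogen with its hydrogen-bond donor, a far larger change than moving two chlorines, and no step among the three compounds lies beyond the scatter. Nothing available explains why the numbers stay level.

Since the nitrogen and the ring substituents changed together, the compounds shown cannot separate their contributions. On these data alone, it also remains open whether an unsubstituted phenyl ring, a carboxylic acid or a longer alkyl chain on this carbonyl carbon would move the number beyond the scatter.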